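This account rests on a few compounds, and the source may have more. Where it says the series, first, only, none or still open, it means among the compounds named here.

Measured compounds: compound 1 `CCCC[C@H](OC(C)=O)c1ccccc1C(=O)O[C@H]1CO[C@H]2[C@@H]1OC[C@H]2OC(=O)c1ccccc1[C@H](CCCC)OC(C)=O` gives 210000 nM in a functional assay on cells (Platelet, Oryctolagus cuniculus) for inhibition, read by turbidimetry, with a stated time of 5 min; on this read-out lower numbers stand for stronger inhibition and higher numbers for weaker inhibition; compound 2 `CCCC[C@H](OC(=O)CN1CCCC1)c1ccccc1C(=O)O[C@H]1CO[C@H]2[C@@H]1OC[C@H]2OC(=O)c1ccccc1[C@H](CCCC)OC(=O)CN1CCCC1` gives 640000 nM in this assay.

Both compounds are two-armed esters built on the same shared core, each arm carrying a butyl side chain and an ester group. Compound 2 stands at the higher of the two numbers in this assay, so it inhibits more weakly than compound 1, and the gap between the two lies beyond the usual scatter. Compound 3 `CCCC[C@@H](OC(=O)CN1CCCC1)c1ccccc1C(=O)O[C@H]1CO[C@H]2[C@@H]1OC[C@H]2OC(=O)c1ccccc1[C@@H](CCCC)OC(=O)CN1CCCC1` has not yet been measured. It differs from compound 2 as follows: the two compounds have the same atoms and bonds and differ only in configuration as drawn: 2 of 6 stereo elements differ; a stereocentre at a saturated chain carbon is drawn S in compound 2 and R in compound 3; a stereocentre at a saturated chain carbon is drawn S in compound 2 and R in compound 3. Going by the values given here, no step between measured compounds addresses such a change in configuration, so nothing here shows how large its effect is or in which direction it runs. The step from compound 2 to compound 3 is therefore expected to be small, no change at the digits printed from compound 2 to compound 3 (within the scatter), with a wide band of uncertainty on either side. For compound 3 a value around 640000 nM is estimated, within the range 150000 nM to 2500000 nM.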

Compound 3, half-maximal inhibitory concentration: 910000 nM
Beside the measured number, compound 3's estimate is 1.4-fold (0.15 log units) below it; measured number inside the range.
By their numbers in this assay, from the lowest: compound 1; then compounds 2 and 3 (each within the scatter of the next).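

In this assay, the change from S to R at both saturated chain carbons gives a 1.4-fold higher number from compound 2 to compound 3 (0.15 log units; within the scatter), so this read-out does not separate the two compounds. Going by these compounds alone, this is the first measured look at configuration at these chain carbons, and with these arms, inverting both carbons together has no effect that can be told from the usual scatter. The comparison is a clean one, as nothing else in the structures varies: the fact that compounds 2 and 3 differ only in the configuration as drawn

As far as these compounds go, it remains open whether inverting only one of the two chain carbons would give the same picture, or whether the same double inversion would read alike with the ester arms of compound 1. Also open, from the compounds shown here alone, is whether configuration here would start to count with a longer chain in place of butyl, or with a carboxylic acid at the end of each arm.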